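A few compounds are considered here, and "the series" means these few. Any claim that something is new, unique, unknown or untested is made for them only; others in the source may bear on it.

In a functional assay on isolated protein for inhibition of Glucose-dependent insulinotropic receptor (Rattus norvegicus), read by HTRF and cAMP accumulation (on this read-out lower numbers stand for smaller maximal responses and higher numbers for larger maximal responses), compound 1 `Cc1nc(S(C)(=O)=O)ccc1Oc1ncnc(OC2CCN(C(=O)OC(C)(C)C(F)(F)F)CC2)c1F` gives 79%. Among the compounds with values here, compound 2 `Cc1nc(S(C)(=O)=O)ccc1Oc1ncnc(OC2CCN(C(=O)OC(C)(C)CF)CC2)c1F` gives 95% in this assay, the higher of the two numbers recorded, and the only measured step so far, a number 16 percentage points higher from compound 1 to compound 2 (beyond the scatter), connects these two compounds through fluoromethyl in place of trifluoromethyl. Compound 3 `Cc1nc(S(C)(=O)=O)ccc1Oc1ncnc(OC2CCN(C(=O)O[C@@H](C)CF)CC2)c1F` has not yet been measured. It differs from compound 2 in one place: 1-(fluoromethyl)ethyl in place of 1-(fluoromethyl)-1-methylethyl on an oxygen next to a carbonyl group. Within the data shown here, the measured step changed the number of fluorines; the change to compound 3 instead drops one carbon and keeps the single fluorine, so no measured step speaks to it directly. With no such guide, the expected step of a number 5 percentage points lower from compound 2 to compound 3 (within the scatter) is none beyond the scatter. Compound 3 is therefore estimated at 90%, with a likely range from 74% to 102%, the width reflecting that the loss of a carbon from this chain has not been tested here.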

Compound 3, largest response reached (reported as efficacy), in percent of the reference or control that the assay uses: 84%
Beside the measured number, compound 3's estimate is 6 percentage points above it, and the stated range covers the measured number.
By their numbers in this assay, from the lowest: compounds 1 and 3 (each within the scatter of the next); then compound 2.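

With the single fluorine kept, 1-(fluoromethyl)ethyl in place of 1-(fluoromethyl)-1-methylethyl on an oxygen next to a carbonyl group gives a number 11 percentage points lower from compound 2 to compound 3 (beyond the scatter) in this assay and so the number at this position responds to the carbon count of the chain as well as to the number of fluorines. Putting the same group in place of 1-methyl-1-(trifluoromethyl)ethyl gives only a number 5 percentage points higher from compound 1 to compound 3 (within the scatter) and so these two chains cannot be told apart here, which leaves 1-(fluoromethyl)-1-methylethyl as the one chain of the three set apart from both others. Nothing available explains why the number moves with these changes.

The compounds shown leave open whether the opposite arrangement at the defined stereocentre of 1-(fluoromethyl)ethyl would give a similar number. They also leave open how a longer chain or a cyclopropyl ring on this oxygen would read.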